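Linker length in a hydroxamic acid series

A few compounds are considered here, and "the series" means these few. Any claim that something is new, unique, unknown or untested is made for them only; others in the source may bear on it.

Measured so far:
compound 1 `O=C(CCCCCCOc1ccc(-c2nnc(-c3ccccc3)s2)cc1)NO`, 64 nM
compound 2 `O=C(CCCCOc1cccc(-c2nnc(-c3ccccc3)s2)c1)NO`, 32 nM

In an assay on HeLa cells for inhibition of protein deacetylase HDAC6 (Homo sapiens), read by fluorescence, with a stated time of 30 min (a higher number here means a weaker inhibitor, a lower number a stronger inhibitor), compound 2 gives the lower of the two numbers, but compound 1 with 64 nM sits within the scatter of it, so no order between them can be claimed. Compound 3 `O=C(CCCCCCOc1cccc(-c2nnc(-c3ccccc3)s2)c1)NO` is not yet measured in this assay. Relative to compound 2 it carries 2-(hydroxycarbamoyl)ethyl in place of hydroxycarbamoyl on a saturated chain carbon, four bonds along the chain from an oxygen on an aromatic ring, a longer chain to the same hydroxamic acid. For the measured compounds named here, no step between measured compounds bears on this change alone, so a step from compound 2 to compound 3 of no size beyond the scatter is expected, a 1.4-fold higher number from compound 2 to compound 3 (0.15 log units; within the scatter). Compound 3 is estimated at 45 nM, range 15 nM to 135 nM.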

Compound 3, half-maximal inhibitory concentration: 185 nM
For compound 3 the middle estimate is 4.1-fold (0.61 log units) below the measured one; the measured number lies above the stated range.
By their numbers in this assay, from the lowest: compounds 2 and 1 (each within the scatter of the next); then compound 3.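

In this assay, for the compounds shown here, 2-(hydroxycarbamoyl)ethyl in place of hydroxycarbamoyl on a saturated chain carbon gives a 5.8-fold higher number from compound 2 to compound 3 (0.76 log units; beyond the scatter) as the first step beyond the scatter. Chain length at this position therefore registers in this read-out, with the longer chain giving the higher number. Nothing at hand accounts for the size of this step.

Two lengths at this position cannot define an optimum. Open, on these data alone, is how (hydroxycarbamoyl)methyl or a longer chain, such as 4-(hydroxycarbamoyl)butyl, would read here.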